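The source may hold more compounds than are shown below. What is called first, only, known or untested is meant among the compounds shown, and "the series" means these compounds.

In a functional assay on HCT-116 cells (Homo sapiens) for antiproliferative activity, read by MTT assay, with a stated time of 72 h (on this read-out lower numbers stand for stronger inhibition and higher numbers for weaker inhibition), compound 1 `O=C(Nc1ccc(Nc2nccc(NC3CCCC3)n2)cc1)Nc1ccc(Cl)c(C(F)(F)F)c1` gives 2510 nM, compound 2 `O=C(Nc1ccc(Nc2nccc(NC3CCCC3)n2)cc1)NC1CCCCC1` gives 1090 nM and compound 3 `O=C(Nc1ccc(Nc2nccc(NC3CCCC3)n2)cc1)Nc1cccc(C(F)(F)F)c1` gives 2410 nM. Compound 3 therefore stands with the higher pair of numbers: the chloro-to-hydrogen change gave a 1.0-fold lower number from compound 1 to compound 3 (0.02 log units; within the scatter), whereas replacing cyclohexyl gave a 2.2-fold higher number from compound 2 to compound 3 (0.34 log units; beyond the scatter). Compound 4 `O=C(Nc1ccc(Cl)cc1)Nc1ccc(Nc2nccc(NC3CCCC3)n2)cc1` carries 4-chlorophenyl in place of 3-(trifluoromethyl)phenyl on an amide-type nitrogen. Within the data shown here, this swaps one substituted phenyl for another, and the only measured change between such groups is a 1.0-fold lower number from compound 1 to compound 3 (0.02 log units; within the scatter). The larger step, a 2.3-fold lower number from compound 1 to compound 2 (0.36 log units; beyond the scatter), involved cyclohexyl and bears less directly. No change beyond the scatter is therefore expected, and the estimated step is a 1.0-fold lower number from compound 3 to compound 4 (0.02 log units; within the scatter). For compound 4, the estimated value is 2300 nM, with an expected range of 1100 nM to 4500 nM.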

Compound 4, half-maximal inhibitory concentration: 5310 nM
For compound 4 the middle estimate is 2.3-fold (0.36 log units) below the measured one; measured number outside the range, above it.
By their numbers in this assay, from the lowest: compound 2; then compounds 3 and 1 (each within the scatter of the next); then compound 4.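

In this assay, the substituents on the phenyl at this amide-type nitrogen prove not to be interchangeable: hydrogen in place of trifluoromethyl gives a 2.1-fold higher number from compound 1 to compound 4 (0.33 log units; beyond the scatter) and 4-chlorophenyl in place of 3-(trifluoromethyl)phenyl gives a 2.2-fold higher number from compound 3 to compound 4 (0.34 log units; beyond the scatter), whereas removing chloro gave only a 1.0-fold lower number from compound 1 to compound 3 (0.02 log units; within the scatter). Against cyclohexyl, 4-chlorophenyl gives a 4.9-fold higher number from compound 2 to compound 4 (0.69 log units; beyond the scatter), a wider gap than the one printed for 3-(trifluoromethyl)phenyl. Nothing available here explains these steps. From the compounds shown here alone, how a methoxy or fluoro on the phenyl would read remains open, as does an open-chain butyl on this nitrogen.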